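This account rests on a few compounds, and the source may have more. Where it says the series, first, only, none or still open, it means among the compounds named here.

The measured compounds:
Compound 1, `Cc1nc(S(C)(=O)=O)ccc1Oc1ncnc(OC2CCN(C(=O)O[C@@H](C)C(F)(F)F)CC2)c1F`, in a functional assay on isolated protein for inhibition of Glucose-dependent insulinotropic receptor (Rattus norvegicus), read by HTRF and cAMP accumulation; on this read-out higher numbers stand for an effect only at larger amounts of compound and lower numbers for an effect already at smaller amounts: 109 nM.
Compound 2, `Cc1nc(S(C)(=O)=O)ccc1Oc1ncnc(OC2CCN(C(=O)OC3(C(F)(F)F)COC3)CC2)c1F`: 342 nM.
Compound 3, `Cc1nc(S(C)(=O)=O)ccc1Oc1ncnc(OC2CCN(C(=O)c3noc(C(C)C)n3)CC2)c1F`: 176 nM.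

Among these three numbers compound 3 stands second highest; its nearest neighbour is compound 1 and its furthest is compound 2, and both of those gaps lie within the scatter. Compound 4, `CCc1cnc(C(=O)N2CCC(Oc3ncnc(Oc4ccc(S(C)(=O)=O)nc4C)c3F)CC2)nc1`, differs from compound 3 by 5-ethylpyrimidin-2-yl in place of 5-isopropyl-1,2,4-oxadiazol-3-yl on a carbonyl carbon. Within the data shown here, no measured step exchanges one aromatic ring for another on that carbonyl carbon. The steps that touch the same position, a 1.6-fold higher number from compound 1 to compound 3 (0.21 log units; within the scatter) and a 1.9-fold lower number from compound 2 to compound 3 (0.29 log units; within the scatter), both fall within the scatter, while a 3.1-fold higher number from compound 1 to compound 2 (0.50 log units; beyond the scatter) is modest. Compound 4 is thus expected to show a step of a 1.1-fold higher number from compound 3 to compound 4 (0.06 log units; within the scatter), nothing beyond the scatter. The estimate for compound 4 is 200 nM, with a range from 80 nM to 500 nM.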

Compound 4, half-maximal effective concentration: 40.8 nM
Beside the measured number, compound 4's estimate is 4.9-fold (0.69 log units) above it, outside the stated range (below it).
By their numbers in this assay, from the lowest: compound 4; then compounds 1, 3 and 2 (each within the scatter of the next, the first and the last beyond it).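

In this assay, the carbonyl carbon now shows a change beyond the scatter from one aromatic ring to another: 5-ethylpyrimidin-2-yl in place of 5-isopropyl-1,2,4-oxadiazol-3-yl gives (a 4.3-fold lower number from compound 3 to compound 4 (0.63 log units; beyond the scatter)). The same ring also separates from both oxygen-linked groups (a 2.7-fold lower number from compound 1 to compound 4 (0.43 log units; beyond the scatter)) and (an 8.4-fold lower number from compound 2 to compound 4 (0.92 log units; beyond the scatter)), so compound 4 has the lowest number of the four. No evidence at hand bears on this result. On these data alone, whether the ring or its ethyl chain carries the step stays open, as does the outcome with a pyridine ring or a propyl chain there.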